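This account rests on a few compounds, and the source may have more. Where it says the series, first, only, none or still open, it means among the compounds named here.

Measured so far:
compound 1, `COc1cc2c(Oc3ccc(NC(=O)c4nn(-c5ccccc5)c(=O)cc4C)cc3F)ccnc2cc1OCCCN1CCCC1`, 460 nM
compound 2, `COc1cc2c(Oc3ccc(NC(=O)c4nn(-c5ccc(Cl)cc5)c(=O)cc4C)cc3F)ccnc2cc1OCCCN1CCCC1`, 360 nM
compound 3, `COc1cc2c(Oc3ccc(NC(=O)c4nn(-c5ccc(Cl)cc5)c(=O)cc4C)cc3F)ccnc2cc1OCCCN1CCCCC1`, 460 nM

All three were tested in a functional assay on NCI-H460 cells (Homo sapiens) for inhibition, read by MTT assay, with a stated time of 72 h; a lower number here means a stronger inhibitor, a higher number a weaker inhibitor. Compound 1 and compound 2 differ by chloro in place of hydrogen on an aromatic carbon, and that change gave a 1.3-fold lower number from compound 1 to compound 2 (0.11 log units; within the scatter). Compound 2 and compound 3 differ by piperidin-1-yl in place of pyrrolidin-1-yl, with a 1.3-fold higher number from compound 2 to compound 3 (0.11 log units; within the scatter). Compound 3 stands level with compound 1 at the digits given, and all three numbers lie within the scatter of one another.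

The unmeasured compound 4 is `COc1cc2c(Oc3ccc(NC(=O)c4nn(-c5ccc(Cl)cc5Cl)c(=O)cc4C)cc3F)ccnc2cc1OCCCN1CCCCC1`. It differs from compound 3 by chloro in place of hydrogen on an aromatic carbon. For the measured compounds named here, this is the same kind of change as the one from compound 1 to compound 2, but not the same: there the chloro entered para to a large group, here it enters ortho to a large group and meta to a chloro group. The difference between the cores of compound 1 and compound 3 is not broken down here.

Because the earlier step of this kind was a 1.3-fold lower number from compound 1 to compound 2 (0.11 log units; within the scatter), compound 4 is expected to show a 1.2-fold lower number from compound 3 to compound 4 (0.06 log units; within the scatter). The estimate for compound 4 in this assay is 400 nM, between 200 nM and 900 nM.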

Compound 4, half-maximal inhibitory concentration: 390 nM
For compound 4 the middle estimate is 1.0-fold (0.01 log units) above the measured one; the measured number falls inside the stated range.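

In this assay, a chloro in place of hydrogen, turning 4-chlorophenyl into 2,4-dichlorophenyl, gave a 1.2-fold lower number from compound 3 to compound 4 (0.07 log units; within the scatter). Set beside the earlier chloro step, the change reads alike on the two cores: the same change on two cores in this assay, a 1.3-fold lower number (0.11 log units; within the scatter) from compound 1 to compound 2 and a 1.2-fold lower number (0.07 log units; within the scatter) from compound 3 to compound 4, 1.1-fold (0.03 log units) apart, within the scatter of two such steps. This does not show that a chloro shifts the number on either core, as each step lies within the scatter, and the new chloro sits ortho to a large group and meta to a chloro group, so the two steps are of one kind but are not the identical change.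

The compounds shown leave open whether another group on that phenyl ring, such as methoxy, trifluoromethyl or a nitrile, would give a step beyond the scatter. They also leave open what a different amine at the end of the chain, such as morpholin-4-yl or 4-methylpiperazin-1-yl, or a longer chain would do in this assay.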